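Swapping furan-2-yl for pyridin-2-yl on the amide carbonyl

The source may report more compounds than this note shows. Statements on the series, on what has been measured and on what is new or still open speak of the compounds shown alone.

Compound 1, `COc1ccc(S(=O)(=O)Oc2ccccc2NC(=O)c2ccc(F)cc2)cc1`, gives 550 nM in a functional assay on NCI-H460 cells (Homo sapiens) for antiproliferative activity; on this read-out lower numbers stand for stronger inhibition and higher numbers for weaker inhibition.
Compound 2, `COc1ccc(S(=O)(=O)Oc2ccccc2NC(=O)c2ccc(N(C)C)cc2)cc1`, reaches only the assay limit of > 10000 nM in this assay.
Compound 3, `COc1ccc(S(=O)(=O)Oc2ccccc2NC(=O)c2ccco2)cc1`, gives 24 nM in this assay.

Compound 3 holds the lowest number of the two numbers shown; its nearest neighbour is compound 1, a step of a 23-fold lower number from compound 1 to compound 3 (1.36 log units; beyond the scatter). Compound 4, `COc1ccc(S(=O)(=O)Oc2ccccc2NC(=O)c2ccccn2)cc1`, differs from compound 3 in one place: pyridin-2-yl in place of furan-2-yl on a carbonyl carbon. Among the measured compounds shown here, the steps that bear on this position are a 23-fold lower number from compound 1 to compound 3 (1.36 log units; beyond the scatter) and an at least 410-fold lower number from compound 2 to compound 3 (2.61 log units; beyond the scatter), both large, and both show that the group on the carbonyl carbon moves the number strongly in this assay. A six-membered ring entering here is therefore expected to raise the number, by a 3.8-fold higher number from compound 3 to compound 4 (0.57 log units; beyond the scatter). Compound 4 is estimated at 90 nM, between 20 nM and 400 nM.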

Compound 4, half-maximal inhibitory concentration: 300 nM
For compound 4 the middle estimate is 3.3-fold (0.52 log units) below the measured one; the measured number falls inside the stated range.
By their numbers in this assay, from the lowest: compound 3; then compounds 4 and 1 (each within the scatter of the next). At a limit, above all of these: compound 2.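

In this assay, a second aromatic ring with one hetero atom does not carry over the low number of furan-2-yl on this carbonyl carbon: a 13-fold higher number from compound 3 to compound 4 (1.10 log units; beyond the scatter). Pyridin-2-yl also cannot be told apart from 4-fluorophenyl here, with a 1.8-fold lower number from compound 1 to compound 4 (0.26 log units; within the scatter), so the gain appears with furan-2-yl alone among these groups. The step of an at least 33-fold lower number from compound 2 to compound 4 (1.52 log units; beyond the scatter) rests on an assay limit: the limit of > 10000 nM in this assay, at which 1 of the 4 values shown sits.

As far as these compounds go, whether the low number is peculiar to furan-2-yl stays open. So does how thiophen-2-yl or pyridin-3-yl on the carbonyl carbon would read.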